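Trifluoromethyl on the outer phenyl of compound 3

A few compounds are considered here, and "the series" means these few. Any claim that something is new, unique, unknown or untested is made for them only; others in the source may bear on it.

In a functional assay on MCF7 cells (Homo sapiens) for antiproliferative activity, read by MTT assay, with a stated time of 72 h (on this read-out higher numbers stand for weaker inhibition and lower numbers for stronger inhibition), compound 3 (`COc1cc(-n2cnc3ccc(-c4ccccc4)cc32)cc(OC)c1OC`) gives 2290 nM. Compound 1 (`COc1cc(-n2cnc3ccc(-c4ccc(C(C)=O)cc4)cc32)cc(OC)c1OC`), which carries a 4-acetylphenyl group, gives 1540 nM, a value within the scatter of compound 3. Compound 2 (`COc1cc(-n2cnc3ccc(-c4cc(F)ccc4F)cc32)cc(OC)c1OC`), with a 2,5-difluorophenyl group, gives 6420 nM and is the weakest of the three, so compound 3 sits with compound 1 at the stronger end of this small set.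

Compound 4 (`COc1cc(-n2cnc3ccc(-c4ccc(C(F)(F)F)cc4)cc32)cc(OC)c1OC`) keeps the shared core and has trifluoromethyl in place of hydrogen on an aromatic carbon, para to a large group: trifluoromethyl in place of hydrogen on an aromatic carbon.

The closest measured precedent is the 4-acetylphenyl group of compound 1, and the step of a 1.5-fold higher number from compound 1 to compound 3 (0.17 log units; within the scatter) shows that exchanging it for hydrogen did not move the number beyond the scatter. The step of a 2.8-fold lower number from compound 2 to compound 3 (0.45 log units; beyond the scatter) is modest but real, so substitution on this phenyl does not always leave the number unchanged. However, compound 2 differs in both its group and its substitution pattern, so it gives no direction for compound 4. No step beyond the scatter is therefore expected, in either direction.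

The estimated step is a 1.1-fold lower number from compound 3 to compound 4 (0.06 log units; within the scatter). For compound 4 the expected value is 2000 nM, with an estimated range from 900 nM to 4500 nM.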

Compound 4, half-maximal inhibitory concentration: 760 nM
Beside the measured number, compound 4's estimate is 2.6-fold (0.42 log units) above it, outside the stated range (below it).
By their numbers in this assay, from the lowest: compound 4; then compounds 1 and 3 (each within the scatter of the next); then compound 2.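

In this assay the outer phenyl proves able to respond to a single group at this place: the step of a 3.0-fold lower number from compound 3 to compound 4 (0.48 log units; beyond the scatter) lies beyond the scatter, whereas the 4-acetylphenyl group of compound 1 had stayed within the scatter of the plain phenyl of compound 3. The identity of the group therefore counts and not merely the presence of one, since trifluoromethyl in place of acetyl gives a 2.0-fold lower number from compound 1 to compound 4 (0.31 log units; beyond the scatter) and the two groups, which sit at the same place, no longer fall together. The step of an 8.4-fold lower number from compound 2 to compound 4 (0.93 log units; beyond the scatter) widens the spread among the outer rings, and with all its steps printed beyond the scatter, compound 4 is the strongest of the four in this assay while the 2,5-difluorophenyl group remains at the weak end.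

Nothing given here explains why trifluoromethyl lowers the number when acetyl does not. Going by these compounds, whether a nitrile, an amine or a carboxylic acid at this place would stand with compound 4 or with compound 3 stays open, as does whether the step would hold on any other cell line.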